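What a carboxy group may do to compound 3

The compounds below may be only part of what the source reports. "The series", "measured", "known", "first", "only" and "open" are said of these compounds alone.

In a functional assay on A2780 cells (Homo sapiens) for antiproliferative activity, read by MTT assay, with a stated time of 48 h (on this read-out higher numbers stand for weaker inhibition and lower numbers for stronger inhibition), compound 1 `COc1ccc(-c2cncc3[nH]c(=O)n(Cc4cc(OC)c(OC)c(OC)c4)c23)cc1O` gives > 20000 nM, a limit of the assay and not a number. Compound 2 `COc1ccc(-c2cncc3[nH]c(=O)n(Cc4cc(OC)c(OC)c(OC)c4)c23)cc1` gives > 20000 nM, again a limit of the assay. Going by the values given here, compound 3 `COc1ccc(-c2cc3c(cn2)[nH]c(=O)n3-c2cc(OC)c(OC)c(OC)c2)cn1` gives 990 nM, the only true number among the three.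

Compound 4 `COc1ccc(-c2cc3c(cn2)[nH]c(=O)n3-c2cc(OC)c(OC)c(OC)c2)cc1C(=O)O` differs from compound 3 in one place: 3-carboxy-4-methoxyphenyl in place of 6-methoxypyridin-3-yl on an aromatic carbon. Here, 3-carboxy-4-methoxyphenyl stands in place of 6-methoxypyridin-3-yl on an aromatic carbon.

Among the compounds with values here, the one measured step, a step that the two limits leave unreadable from compound 1 to compound 2, puts hydrogen in place of hydroxy, and it offers no size to carry over. Within the data shown here, no measured step makes this same exchange. The nearest hint is indirect: compound 1 and compound 2 also carry a methoxy-bearing aromatic ring of carbon only, although their cores differ from that of compound 3, and the evidence on them is the limit of > 20000 nM in this assay, at which 2 of the 3 values shown sit. On that weak ground, a move towards weaker inhibition in this assay is expected, well beyond the usual scatter. The expected change is an estimated 9.1-fold higher number from compound 3 to compound 4 (0.96 log units; beyond the scatter). For compound 4 the estimate is 9000 nM, with an expected range from 2000 nM to 30000 nM.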

Compound 4, half-maximal inhibitory concentration: 4120 nM
For compound 4 the middle estimate is 2.2-fold (0.34 log units) above the measured one; the range from low to high includes it.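

In this assay, the exchange of 6-methoxypyridin-3-yl for 3-carboxy-4-methoxyphenyl gives a 4.2-fold higher number from compound 3 to compound 4 (0.62 log units; beyond the scatter). This is the only step among the compounds shown that can be read, since the one between compound 1 and compound 2 cannot. The change is real but modest: this aromatic carbon of the six-membered ring with 1 nitrogen accepts a group with more heavy atoms, including a carboxy group, and compound 4 still gives a true number, not a limit of the assay, while the limit elsewhere in the set offers no cause for the step: the limit of > 20000 nM in this assay, at which 2 of the 4 values shown sit.

The exchange removes a ring nitrogen and brings in a carboxy group in a single move, so the compounds shown cannot say how much of the step belongs to each part. A plain 4-methoxyphenyl group at this place would separate the two, and a methyl ester or a primary amide in place of the carboxylic acid would show whether the acid itself matters.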